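Oxime series: methoxy for bromo and tolerated concentration

This account rests on a few compounds, and the source may have more. Where it says the series, first, only, none or still open, it means among the compounds named here.

Measured compounds:
compound 1, `COc1ccc(/C=C/C(=N\O)c2ccc(Br)cc2)cc1`, 23700 nM
compound 2, `Cc1ccc(C(/C=C/c2ccc(Br)cc2)=N/O)cc1`, 34200 nM

In an ADME assay on cells (Mus musculus, strain Balb/c) for cytotoxicity, read by MTT assay, with a stated time of 48 h (a higher number here means that more compound is tolerated, a lower number that less compound is tolerated), compound 2 gives 34200 nM, the higher of the two numbers, while compound 1 gives 23700 nM; the gap between them lies within the scatter, so the two stand level. The next compound, compound 3 `COc1ccc(/C=C/C(=N\O)c2ccc(C)cc2)cc1`, has not yet been measured in this assay. Compared with compound 2 it carries methoxy in place of bromo on an aromatic carbon, on an aromatic carbon of a six-membered aromatic ring of carbon only. Going by the values given here, no measured pair shows this change, so its size is unknown. Because compound 1 gives 23700 nM and compound 2 gives 34200 nM, a pair that stands level, the expected step is a 1.2-fold higher number from compound 2 to compound 3 (0.07 log units; within the scatter), staying within the scatter and leaning slightly upward. Compound 3 is therefore estimated at 40000 nM, within a range of 15000 nM to 100000 nM.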

Compound 3, half-maximal cytotoxic concentration: 117000 nM
Compound 3: the middle estimate sits 2.9-fold (0.47 log units) below what was measured, outside the stated range (above it).
By their numbers in this assay, from the lowest: compounds 1 and 2 (each within the scatter of the next); then compound 3.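

In this assay the bromo on an aromatic carbon proves not to be a neutral feature: methoxy in place of bromo gives a 3.4-fold higher number from compound 2 to compound 3 (0.53 log units; beyond the scatter) and methyl in place of bromo gives a 4.9-fold higher number from compound 1 to compound 3 (0.69 log units; beyond the scatter) in the same direction. Both steps remove a bromo, and compound 3, the only one of the three without it, stands apart with the higher number, while the two compounds that carry bromo stand level. Nothing shown here gives a reason for this rise.

On these data alone, with only these three compounds, it remains open whether the rise follows from losing the bromo or from the particular group that enters. Also open, as far as these compounds go, is how a chloro, a hydroxyl, an amine or a carboxylic acid would compare on the same aromatic carbon.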